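One More Aryl Swap on the Amide

The source may report more compounds than this note shows. Statements on the series, on what has been measured and on what is new or still open speak of the compounds shown alone.

Compound 1 `O=C(CCC(=O)OCCCCCCSc1ccc([N+](=O)[O-])c2nonc12)Nc1ccccc1Cl`: 2430 nM
Compound 2 `COc1ccc(NC(=O)CCC(=O)OCCCCCCSc2ccc([N+](=O)[O-])c3nonc23)cc1`: 3060 nM

Within the data shown here, both compounds were measured in a functional assay on 143B cells (Homo sapiens) for inhibition, read by MTT assay, with a stated time of 72 h (a higher number here means a weaker inhibitor, a lower number a stronger inhibitor), and their values lie within the usual scatter of each other, so compound 2 stands level with compound 1 on the numbers so far. Compound 3 `O=C(CCC(=O)OCCCCCCSc1ccc([N+](=O)[O-])c2nonc12)Nc1ccc(F)c(Cl)c1` keeps everything in compound 2 except one group: 3-chloro-4-fluorophenyl in place of 4-methoxyphenyl on an amide-type nitrogen. In words, it has 3-chloro-4-fluorophenyl in place of 4-methoxyphenyl on an amide-type nitrogen.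

Among the measured compounds shown here, only one measured step bears on this change. It concerns the same nitrogen, where 4-methoxyphenyl took the place of 2-chlorophenyl, and it gave a 1.3-fold higher number from compound 1 to compound 2 (0.10 log units; within the scatter) in this assay. A single step within the scatter is thin evidence, and it says nothing about this new group in particular. Still, it gives no ground to expect a large move, and no step beyond the scatter is expected in either direction. The expected change is a 1.2-fold lower number from compound 2 to compound 3 (0.07 log units; within the scatter) for this swap. Compound 3 is therefore estimated at 2600 nM in this assay, with an expected range from 1200 nM to 5500 nM for the coming measurement.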

Compound 3, half-maximal inhibitory concentration: 2990 nM
Compound 3: middle estimate off by 1.2-fold (0.06 log units), on the low side, within the range that was stated.
By their numbers in this assay, from the lowest: compounds 1, 3 and 2 (each within the scatter of the next).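

Swapping 4-methoxyphenyl for 3-chloro-4-fluorophenyl on the amide-type nitrogen gives a 1.0-fold lower number from compound 2 to compound 3 (0.01 log units; within the scatter) in this assay, and the other available comparison, with 2-chlorophenyl as the starting group, gives a 1.2-fold higher number from compound 1 to compound 3 (0.09 log units; within the scatter). Among these compounds, the earlier pair showed only that two aryl groups could read alike here, whereas three now do, and this third group has two halogens on its ring, while the group it replaces carries a hydrogen-bond acceptor and it carries none. Across these three compounds, then, this position has not yet shown a change beyond the scatter, and nothing shown explains why the numbers stay so close.

From the compounds shown here alone, all three groups on this nitrogen are substituted phenyl rings, so it remains open whether a non-aromatic group such as cyclohexyl, or a phenyl bearing an amine or a carboxylic acid, would shift the number beyond the scatter. The compounds shown also share the same chain and core, so they cannot tell whether a longer chain would leave this flat picture at the amide nitrogen intact.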